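Swapping the aryl group on a free-piperazine dithiocarbamate

The compounds below may be only part of what the source reports. "The series", "measured", "known", "first", "only" and "open" are said of these compounds alone.

Measured compounds:
compound 1, `O=C(OCc1ccccc1)N1CCN(C(=S)SCc2cn(Cc3ccc(F)cc3)nn2)CC1`: 17600 nM
compound 3, `O=C(OCc1ccccc1)N1CCN(C(=S)SCc2cn(Cc3ccc(Cl)c(Cl)c3)nn2)CC1`: 7140 nM
compound 2, `S=C(SCc1cn(Cc2ccc(Cl)c(Cl)c2)nn1)N1CCNCC1`: "not determined" (no result reported)

In a functional assay on MGC-803 cells (Homo sapiens) for inhibition, read by MTT assay, with a stated time of 72 h (on this read-out higher numbers stand for weaker inhibition and lower numbers for stronger inhibition), compound 1 gives 17600 nM, and compound 3 gives 7140 nM. For the measured compounds named here, these two share the whole core and differ only in the aryl group, and the step of a 2.5-fold lower number from compound 1 to compound 3 (0.39 log units; beyond the scatter) is the only measured step here. Going by these compounds, for compound 2 the result in this assay is "not determined" (no result reported), so its standing is unknown; its core carries a free piperazine where compounds 1 and 3 carry a benzyl carbamate.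

Compound 4, `Cc1ccc(Cn2cc(CSC(=S)N3CCNCC3)nn2)cc1`, is compound 2 with the change (4-methylphenyl in place of 3,4-dichlorophenyl on a saturated chain carbon bound to an aromatic nitrogen). The step of a 2.5-fold lower number from compound 1 to compound 3 (0.39 log units; beyond the scatter) bears on it only loosely, since it concerns a different aryl swap at the same place and a different core. Without a number for compound 2, the expectation for compound 4 rests on compounds 1 and 3 alone, with wide uncertainty about the free piperazine. Compound 4 is therefore expected to give about 20000 nM in this assay, in a range from 5000 nM to 80000 nM.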

Compound 4, half-maximal inhibitory concentration: 64300 nM
The estimate for compound 4 lay 3.2-fold (0.51 log units) below the measured number; the range from low to high includes it.
By their numbers in this assay, from the lowest: compound 3; then compound 1; then compound 4.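

Compound 4 differs in one place only from compound 2, which has no number to compare with, so no new step can be read. Still open, going by these compounds, is how 4-methylphenyl and 3,4-dichlorophenyl compare on this core, and how this core compares with that of compound 1 and compound 3. Nothing shown accounts for the result of compound 4.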